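This account rests on a few compounds, and the source may have more. Where it says the series, first, only, none or still open, it means among the compounds named here.

Measured compounds in an assay on COS-7 cells for agonist activity at Free fatty acid receptor 1 (Homo sapiens), read by scintillation counting and inositol phosphate accumulation, with a stated time of 90 min; a higher number here means that more compound is needed for the effect, a lower number that less compound is needed:
- compound 1 `Cc1ccc(Nc2nc(N)nc(COc3ccc4c(C)cc(=O)oc4c3)n2)cc1`: 1790 nM
- compound 2 `Cc1c(Cl)cc(Nc2nc(N)nc(COc3ccc4c(C)cc(=O)oc4c3)n2)cc1Cl`: 600 nM

Compound 2 gives the lowest of the two numbers in this assay; its nearest neighbour is compound 1, and the difference between them is a 3.0-fold lower number from compound 1 to compound 2 (0.47 log units; beyond the scatter), a modest step that arises from 3,5-dichloro-4-methylphenyl in place of 4-methylphenyl on a nitrogen on an aromatic ring. Compound 3 `Cc1cc(=O)oc2cc(OCc3nc(N)nc(NCc4ccc(F)cc4)n3)ccc12` is the next compound to be measured. It differs from compound 2 as follows: 4-fluorobenzyl in place of 3,5-dichloro-4-methylphenyl on a nitrogen on an aromatic ring. Within the data shown here, the one measured step concerns substituents on the phenyl ring itself, whereas the change to compound 3 exchanges the whole aryl group for a benzyl, so no measured step bears directly on it. Without a guiding step, compound 3 is estimated to give 1200 nM (range 300 nM to 5000 nM), which means an expected step of a 2.0-fold higher number from compound 2 to compound 3 (0.30 log units; within the scatter).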

Compound 3, half-maximal effective concentration: 7820 nM
Compound 3: middle estimate off by 6.5-fold (0.81 log units), on the low side, outside the stated range (above it).
By their numbers in this assay, from the lowest: compound 2; then compound 1; then compound 3.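

On the nitrogen on an aromatic ring, this assay shows that this place tolerates exchange of the aryl group less well than the earlier ring substitution suggested: 4-fluorobenzyl in place of 3,5-dichloro-4-methylphenyl gives a 13-fold higher number from compound 2 to compound 3 (1.12 log units; beyond the scatter). The smaller comparison, 4-fluorobenzyl in place of 4-methylphenyl, gives a 4.4-fold higher number from compound 1 to compound 3 (0.64 log units; beyond the scatter), so among these three compounds both with a phenyl group on the nitrogen give lower numbers than the one with a benzyl group. Each step changes the ring substituents as well as replacing phenyl with benzyl, so the two changes cannot be separated. Nothing shown gives a reason for these steps. The compounds shown leave open how an unsubstituted benzyl or a 3,5-dichloro-4-methylbenzyl would read here, and whether a 4-fluorophenyl would behave like the other phenyl groups.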